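Coumarin-triazole dienone series: methoxyphenyl positional change

This account rests on a few compounds, and the source may have more. Where it says the series, first, only, none or still open, it means among the compounds named here.

Measured so far in a functional assay on THP-1 cells (Homo sapiens) for inhibition, read by sulforhodamine B assay, with a stated time of 48 h, tested at 50 uM; a higher number here means more inhibition of growth at the concentration tested, a lower number less inhibition of growth:
compound 1 `COc1ccccc1/C=C/C(=O)/C=C/c1ccc(OCc2cn(CCCCOc3cc(=O)oc4ccccc34)nn2)c(OC)c1`, 40%
compound 2 `COc1cc(/C=C/C(=O)/C=C/c2cc(OC)c(OC)c(OC)c2)ccc1OCc1cn(CCCOc2cc(=O)oc3ccccc23)nn1`, 79%
compound 3 `COc1cc(/C=C/C(=O)/C=C/c2ccco2)ccc1OCc1cn(CCCCCOc2cc(=O)oc3ccccc23)nn1`, 39%

Compound 1 stands second highest of the three numbers. Its nearest neighbour is compound 3, whose value lies within the usual scatter of that of compound 1, so no order between these two can be read. Compound 2 lies well beyond the scatter above compound 1, the only clear separation in this set.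

The next compound, compound 4 `COc1cccc(/C=C/C(=O)/C=C/c2ccc(OCc3cn(CCCCOc4cc(=O)oc5ccccc45)nn3)c(OC)c2)c1`, has the same atoms as compound 1 joined differently: 3-methoxyphenyl in place of 2-methoxyphenyl on a double-bonded chain carbon bound to a double-bonded chain carbon. Among the measured compounds shown here, no pair of measured compounds shows this kind of change, so nothing in the present numbers tells how the position of the methoxy group on that phenyl ring affects growth inhibition. The two measured compounds nearest to compound 1 in value differ from it in other places entirely.

Compound 4 is therefore expected to stay close to compound 1, with a step of a number 2 percentage points higher from compound 1 to compound 4 (within the scatter) that is not expected to exceed the scatter in either direction. The estimate for compound 4 is 42%, within a range of 25% to 60%.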

Compound 4, percent growth inhibition at one concentration: 47%
Beside the measured number, compound 4's estimate is 5 percentage points below it, and the stated range covers the measured number.
By their numbers in this assay, from the lowest: compounds 3, 1 and 4 (each within the scatter of the next); then compound 2.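

Among the compounds shown here, the step in this assay is the first that isolates a single place: with 3-methoxyphenyl in place of 2-methoxyphenyl on a double-bonded chain carbon bound to a double-bonded chain carbon, it reads a number 7 percentage points higher from compound 1 to compound 4 (within the scatter) and the chain and the rest of the core stay the same. This change of methoxy position on the phenyl ring therefore gives no separation between the two compounds at the single concentration tested. No measurement on hand bears on the reason for this result.

Still open, going by these compounds, is whether an amine or a carboxylic acid in place of the methoxy group on that phenyl ring would move growth inhibition beyond the scatter. On these data alone, compound 2 differs from compound 1 and compound 4 in more than one place, so the source of its separation also stays open.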